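Carboxylic acid in place of the anilide on compound 1

A few compounds are considered here, and "the series" means these few. Any claim that something is new, unique, unknown or untested is made for them only; others in the source may bear on it.

Measured so far in a functional assay on CCRF-CEM cells (Homo sapiens) for inhibition, read by MTT assay, with a stated time of 2 days, tested at 10 uM; a higher number here means more inhibition at the concentration tested (going by the name of the read-out), a lower number less inhibition:
compound 1 `COc1ccc(OC)c(-c2cn(-c3ccc(O)c(C(=O)Nc4cccc(C(F)(F)F)c4)c3)nn2)c1` gives 15%
compound 2 `COc1ccccc1-c1cn(-c2ccc(O)c(C(=O)Nc3cccc(C(F)(F)F)c3)c2)nn1` gives 65%
compound 3 `COC(=O)c1cc(-n2cc(-c3ccc(OC)cc3)nn2)ccc1O` gives 16%

Going by the values given here, compound 1 stands lowest of the three numbers; compound 3 sits within the scatter of it, while compound 2 lies well beyond it, the step of a number 50 percentage points higher from compound 1 to compound 2 (beyond the scatter) being the only measured step in the set (hydrogen in place of methoxy on an aromatic carbon).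

The next compound, compound 4 `COc1ccc(OC)c(-c2cn(-c3ccc(O)c(C(=O)O)c3)nn2)c1`, differs from compound 1 by hydroxy in place of (3-(trifluoromethyl)phenyl)amino on a carbonyl carbon, with the hydroxy entering on the carbonyl carbon whose other neighbour is an aromatic carbon. Among the compounds with values here, no measured step covers a change at the carbonyl carbon, so the measured step from compound 1 to compound 2 does not bear on it. Within the data shown here, the only hint is compound 3, which carries a methyl ester rather than the anilide and gives a number within the scatter of compound 1. Both the low starting point of compound 1 and the low value of compound 3 point to little change.

Compound 4 is therefore expected near 12% in this assay, with a range from 0% to 30%. The expected step of a number 3 percentage points lower from compound 1 to compound 4 (within the scatter) is estimated to stay within the scatter.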

Compound 4, a percentage reported as inhibition, at one concentration (the size of the read-out at that concentration, not a potency): 9%
Estimate against measurement, compound 4: 3 percentage points above; the range from low to high includes it.
By their numbers in this assay, from the lowest: compounds 4, 1 and 3 (each within the scatter of the next); then compound 2.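

In this assay, going by these compounds alone, the change at the carbonyl carbon, hydroxy in place of (3-(trifluoromethyl)phenyl)amino, gives a number 6 percentage points lower from compound 1 to compound 4 (within the scatter) and is the only step read at this position. With compound 1 at 15% there is little room for a fall, so the step shows only that, with the substituents of compound 1 in place, the number stays low without the (3-(trifluoromethyl)phenyl)amino group, not that the group is without a role elsewhere in the series. No measured property is available to explain this result.

On these data alone, the same exchange on compound 2, at 65%, would test the position from a higher starting value, and that comparison remains open. Also open, as far as these compounds go, is how a plain amino group or a morpholine on the same carbonyl carbon would read in this assay on either background.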